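Amine substituent changes on a shared-core series

The source may report more compounds than this note shows. Statements on the series, on what has been measured and on what is new or still open speak of the compounds shown alone.

Measured compounds so far:
Compound 1, `O=C1C=C(NCc2ccccc2)C(=O)c2c1nc1n2[C@H]2OC[C@@H](O)[C@H]2OC1`. In a functional assay on HeLa cells (Homo sapiens) for inhibition, read by sulforhodamine B assay (a lower number here means a stronger inhibitor, a higher number a weaker inhibitor), compound 1 reaches only the limit > 8000 nM, not a number.
Compound 2, `CCc1ccc(NC2=CC(=O)c3c(nc4n3[C@H]3OC[C@@H](O)[C@H]3OC4)C2=O)cc1`. In this assay compound 2 gives 6510 nM.
Compound 3, `O=C1C=C(Nc2ccccc2)C(=O)c2c1nc1n2[C@H]2OC[C@@H](O)[C@H]2OC1`. In this assay compound 3 gives 5620 nM.

Compound 2 stands highest of the two numbers, with compound 3 nearest at a gap that lies within the scatter, so no order between the two can be read. One value sits at a limit (the limit of > 8000 nM in this assay, at which 1 of the 3 values shown sits).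

Among the compounds with values here, the only measured step is an at least 1.4-fold lower number from compound 1 to compound 3 (0.15 log units; that floor lies within the scatter), phenyl in place of benzyl on the amine nitrogen; its floor lies within the scatter, and it says only that the group on this nitrogen can move the number.

The unmeasured compound 4 is `O=C1C(NC2CCCCC2)=CC(=O)c2c1nc1n2[C@H]2OC[C@@H](O)[C@H]2OC1`. The change from compound 2 is cyclohexyl in place of 4-ethylphenyl on an amine nitrogen. Within the data shown here, no measured step swaps an aromatic ring for a saturated one at this position, so the step from compound 2 to compound 4 in this assay is expected to stay within the scatter, with a limit result possible.

For compound 4 the estimate is 7000 nM, between 3000 nM and 16000 nM. The step this estimate means is a 1.1-fold higher number from compound 2 to compound 4 (0.03 log units; within the scatter).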

Compound 4, half-maximal inhibitory concentration: > 16000 nM
Compound 4: only a limit was reported (the forecaster's own chance of this, stated with the estimate: 35%); middle value at least 2.2-fold (0.35 log units) away from the limit.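

In this assay, within the data shown here, cyclohexyl in place of 4-ethylphenyl on the amine nitrogen gives an at least 2.4-fold higher number from compound 2 to compound 4 (0.39 log units; beyond the scatter), the first step at this position that is printed as beyond the scatter. Among these compounds, the earlier step, an at least 1.4-fold lower number from compound 1 to compound 3 (0.15 log units; that floor lies within the scatter), had a floor within the scatter, so only this new step shows that the group on this nitrogen moves the number by more than repeat measurements would. Compound 4 gives only a limit, not a number, so the step is a floor and its true size stays unknown: the limit of > 16000 nM in this assay, at which 1 of the 4 values shown sits.

This change replaces the aromatic ring with a saturated one and removes the ethyl group in the same step, so the compounds shown cannot separate the two or say which of them carries the loss, and with only four compounds on the shared core, none of them reaching a strong number, no wider trend can be drawn. Still open, on these data alone, is how a pyridyl ring, a hydroxyl group on the phenyl ring or a morpholine on this nitrogen would read in this assay, and whether any group here brings the number well below those of compound 2 and compound 3.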